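The source may hold more compounds than are shown below. What is called first, only, known or untested is meant among the compounds shown, and "the series" means these compounds.

Compound 2 `Cc1ccc(S(=O)(=O)/N=C(/CCNC2=CC(=O)c3ccccc3C2=O)Nc2ccccc2[N+](=O)[O-])cc1` gives 5010 nM in a functional assay on A549 cells (Homo sapiens) for cytotoxicity, read by MTT assay, with a stated time of 48 h (on this read-out higher numbers stand for weaker inhibition and lower numbers for stronger inhibition), the lowest of the three numbers in hand. Compound 1 `Cc1ccc(S(=O)(=O)/N=C(/CCNC2=CC(=O)c3ccccc3C2=O)Nc2ccc(Cl)cc2)cc1` gives 29900 nM and compound 3 `Cc1ccc(S(=O)(=O)/N=C(/CCNC2=CC(=O)c3ccccc3C2=O)Nc2cccc(C)c2)cc1` gives 18700 nM. The steps of a 6.0-fold lower number from compound 1 to compound 2 (0.78 log units; beyond the scatter) and a 3.7-fold higher number from compound 2 to compound 3 (0.57 log units; beyond the scatter) both set the 2-nitrophenyl member apart, whereas a 1.6-fold lower number from compound 1 to compound 3 (0.20 log units; within the scatter) stays within the scatter. Compound 4 `Cc1ccc(S(=O)(=O)/N=C(/CCNC2=CC(=O)c3ccccc3C2=O)Nc2cccc(C(F)(F)F)c2)cc1` carries the change (3-(trifluoromethyl)phenyl in place of 2-nitrophenyl on an amine nitrogen). The step bearing most directly on it is a 3.7-fold higher number from compound 2 to compound 3 (0.57 log units; beyond the scatter), where the 2-nitrophenyl likewise gave way to a substituted phenyl on an amine nitrogen; a rise of comparable size is therefore expected in this assay. The estimate for compound 4 is 15000 nM, with a range of 6000 nM to 40000 nM, which is an expected step of a 3.0-fold higher number from compound 2 to compound 4 (0.48 log units; beyond the scatter).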

Compound 4, half-maximal inhibitory concentration: 78500 nM
Compound 4: middle estimate off by 5.2-fold (0.72 log units), on the low side, outside the stated range (above it).
By their numbers in this assay, from the lowest: compound 2; then compounds 3 and 1 (each within the scatter of the next); then compound 4.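

On the amine nitrogen, the choice of phenyl substituent carries more weight than the first three compounds showed: a 16-fold higher number from compound 2 to compound 4 (1.20 log units; beyond the scatter) is the largest step in the series. The 3-(trifluoromethyl)phenyl member also separates from the 4-chlorophenyl member, with a 2.6-fold higher number from compound 1 to compound 4 (0.42 log units; beyond the scatter) as the step. Exchanging a single group on the aromatic carbon is enough to move the number, as a 4.2-fold higher number from compound 3 to compound 4 (0.62 log units; beyond the scatter) shows for trifluoromethyl in place of methyl, leaving compound 4 the weakest of the four.

Nothing available accounts for these gaps. Going by these compounds, whether compound 2 stands apart for its nitro group or for that group's place stays open, as does how a nitrile or a carboxylic acid on this phenyl would read.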